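The source may hold more compounds than are shown below. What is called first, only, known or untested is meant among the compounds shown, and "the series" means these compounds.

Measured compounds:
Compound 1, `C=C(Br)C(=O)Nc1cccc(-c2cn3nc(Cc4cccc(OC)c4)sc3n2)c1`: 3100 nM
Compound 2, `C=C(Br)C(=O)Nc1cccc(-c2cn3nc(-c4ccccc4)sc3n2)c1`: 960 nM
Compound 3, `C=C(Br)C(=O)Nc1cccc(-c2cn3nc(-c4ccc(C)cc4)sc3n2)c1`: 1700 nM

These three compounds share a core and differ only in the group on the aromatic carbon of the fused five-membered ring. In a functional assay on CCRF-CEM cells (Homo sapiens) for inhibition, read by cell counting, with a stated time of 3 days (a higher number here means a weaker inhibitor, a lower number a stronger inhibitor), compound 3 sits between compound 1 and compound 2, yet a 1.8-fold higher number from compound 2 to compound 3 (0.25 log units; within the scatter) and a 1.8-fold lower number from compound 1 to compound 3 (0.26 log units; within the scatter) both fall within the scatter, so compound 3 is not clearly separated from either. Among the measured compounds shown here, only a 3.2-fold lower number from compound 1 to compound 2 (0.51 log units; beyond the scatter) is beyond the scatter, and it places compound 1, the one compound whose aromatic ring hangs from a chain, at the weak end.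

Compound 4, `C=C(Br)C(=O)Nc1cccc(-c2cn3nc(CCc4ccccc4)sc3n2)c1`, has not yet been measured in this assay. It differs from compound 3 by phenethyl in place of 4-methylphenyl on an aromatic carbon. The step most relevant is the one from the chain-linked ring of compound 1 to the directly attached ring of compound 3, a 1.8-fold lower number from compound 1 to compound 3 (0.26 log units; within the scatter), which was within the scatter, supported by a 3.2-fold lower number from compound 1 to compound 2 (0.51 log units; beyond the scatter) in the same direction. Since compound 4 returns to a chain-linked ring, a modest rise toward compound 1 is expected, a 1.5-fold higher number from compound 3 to compound 4 (0.17 log units; within the scatter). Compound 4 is therefore expected to give about 2500 nM, in a range from 1100 nM to 5500 nM.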

Compound 4, half-maximal inhibitory concentration: 4200 nM
The estimate for compound 4 lay 1.7-fold (0.23 log units) below the measured number; the measured number falls inside the stated range.
By their numbers in this assay, from the lowest: compounds 2, 3, 1 and 4 (each within the scatter of the next, the first and the last beyond it).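

In this assay, phenethyl on this aromatic carbon gives a 2.5-fold higher number from compound 3 to compound 4 (0.39 log units; beyond the scatter), so a chain-linked ring now stands clearly apart from the 4-methylphenyl group, a separation that compound 1 did not establish against compound 3. The gap from the unsubstituted directly attached ring is wider still, at a 4.4-fold higher number from compound 2 to compound 4 (0.64 log units; beyond the scatter), and it is the largest step among the compounds shown. Compound 4 and compound 1 are not separated, with a 1.4-fold higher number from compound 1 to compound 4 (0.13 log units; within the scatter), so phenethyl and 3-methoxybenzyl cannot be told apart here; the two chain-linked compounds lie on the weaker side of compound 2, while compound 1 against compound 3 remains the exception to a clean split between chain-linked and directly attached rings.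

The compounds shown leave open how an unsubstituted benzyl, a longer chain ending in phenyl, a directly attached cyclohexyl, or an amine or carboxylic acid on the ring would behave at this position. Nothing available beyond these cell numbers accounts for the difference between the chain-linked and directly attached groups.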